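Cationic headgroup swap on a quinolone amide series

The source may hold more compounds than are shown below. What is called first, only, known or untested is meant among the compounds shown, and "the series" means these compounds.

Compound 1 `Cc1cc(OCCCCCCC[N+]2(C)CCCCC2)ccc1-n1cc(C(=O)Nc2cc(F)cc(F)c2)c(=O)c2ccc(N(C)C)nc21` is reported as "not active" (no number reported) in an assay on LX2 cells for inhibition of COL1A1 promoter (Homo sapiens), read by a luciferase reporter, with a stated time of 24 h, tested at 20 uM (a higher number here means a stronger effect of the compound at the concentration tested, a lower number a weaker effect), without a number. Going by the values given here, compound 2 `Cc1cc(OCCCCCCC[N+]2(C)CCCCC2)cc(-n2cc(C(=O)Nc3cc(F)cc(F)c3)c(=O)c3ccc(N(C)C)nc32)c1` gives 46.8% in this assay, the only number so far recorded. Compound 3 `Cc1cc(OCCCCCCC[N+]2(C)CCN(C)CC2)cc(-n2cc(C(=O)Nc3cc(F)cc(F)c3)c(=O)c3ccc(N(C)C)nc32)c1` differs from compound 2 by a group of 8 heavy atoms (6 carbon, 2 nitrogen; one six-membered non-aromatic ring with 2 hetero atoms) in place of a group of 7 heavy atoms (6 carbon, 1 nitrogen; one six-membered non-aromatic ring with 1 hetero atom), on a saturated chain carbon, seven bonds along the chain from an oxygen on an aromatic ring. Among the compounds with values here, no step between two measured compounds is available to guide the size of this change, so the account expects a step from compound 2 to compound 3 of a number 4.8 percentage points lower from compound 2 to compound 3 (within the scatter), within the usual scatter and leaning slightly lower. Compound 3 is therefore estimated at 42% in this assay, with a range from 25% to 60%.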

Compound 3, a percentage reported as inhibition, at one concentration (the size of the read-out at that concentration, not a potency): 2.8%
For compound 3 the middle estimate is 39.2 percentage points above the measured one; measured number below the stated range.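

Exchanging the ring with 1 hetero atom for the ring with 2 hetero atoms gives a number 44 percentage points lower from compound 2 to compound 3 (beyond the scatter) in this assay and so shows that the read-out depends strongly on the headgroup at this place. Both groups carry a net charge of +1, so keeping that charge alone does not keep the read-out. No measurement shown accounts for this drop.

Going by these compounds, whether a morpholine ring or a pyrrolidine ring here would match compound 2 or compound 3 remains open. So does whether a shorter chain would alter the effect of this swap.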